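Diethylamino for Dimethylamino Carried onto a Second Core

The source may report more compounds than this note shows. Statements on the series, on what has been measured and on what is new or still open speak of the compounds shown alone.

The measured compounds in a functional assay on A549 cells (Homo sapiens) for cytotoxicity, read by MTT assay, with a stated time of 72 h; on this read-out higher numbers stand for weaker inhibition and lower numbers for stronger inhibition:
compound 1, `CN(C)Cc1ccc2nc(NC(=O)N/N=C3\C(=O)Nc4ccc(F)cc43)sc2c1`, gives 2310 nM
compound 2, `CCN(CC)Cc1ccc2nc(NC(=O)N/N=C3\C(=O)Nc4ccc(F)cc43)sc2c1`, gives 2010 nM
compound 3, `CN(C)Cc1ccc2nc(NC(=O)N/N=C/c3cn(Cc4ccc(Cl)c(Cl)c4)c4ccccc34)sc2c1`, gives 940 nM

Compound 2 differs from compound 1 by diethylamino in place of dimethylamino on a saturated chain carbon bound to an aromatic carbon, and in this assay this gave a 1.1-fold lower number from compound 1 to compound 2 (0.06 log units; within the scatter). Compound 3 carries a different core; the difference between the two cores is not broken down here. Compound 4, `CCN(CC)Cc1ccc2nc(NC(=O)N/N=C/c3cn(Cc4ccc(Cl)c(Cl)c4)c4ccccc34)sc2c1`, has not yet been measured and differs from compound 3 by diethylamino in place of dimethylamino on a saturated chain carbon bound to an aromatic carbon, the same change as that from compound 1 to compound 2, at the same place. The expected step is therefore a 1.1-fold lower number from compound 3 to compound 4 (0.04 log units; within the scatter), set beside a 1.1-fold lower number from compound 1 to compound 2 (0.06 log units; within the scatter), resting on the fact that the earlier step was within the scatter. Compound 4 is expected to give 850 nM, with a range from 450 nM to 1700 nM.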

Compound 4, half-maximal inhibitory concentration: 1470 nM
For compound 4 the middle estimate is 1.7-fold (0.24 log units) below the measured one; the range from low to high includes it.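

In this assay, diethylamino in place of dimethylamino gave a 1.6-fold higher number from compound 3 to compound 4 (0.19 log units; within the scatter), so on the second core, as on the first, the step stayed within the scatter. Set side by side, the two steps do not differ: the same change on two cores in this assay, a 1.1-fold lower number (0.06 log units; within the scatter) from compound 1 to compound 2 and a 1.6-fold higher number (0.19 log units; within the scatter) from compound 3 to compound 4, 1.8-fold (0.25 log units) apart, within the scatter of two such steps. This shows that the change carried from one core to the other without a step beyond the scatter, but it does not show that the two cores respond identically, and it says nothing about any further core.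

The compounds shown leave open whether dipropylamino, a longer chain, would give a step beyond the scatter at the same place on either core. They also leave open how a primary amine or a carboxylic acid there would read.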